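A Nitro Swap at the Assay Limit

The compounds below may be only part of what the source reports. "The series", "measured", "known", "first", "only" and "open" are said of these compounds alone.

Measured in a functional assay on K562 cells (Homo sapiens) for cytotoxicity, read by sulforhodamine B assay; on this read-out higher numbers stand for lower toxicity in this test and lower numbers for higher toxicity in this test:
- Compound 1 `CC1=CC[C@@H]([C@@](C)(O)CCCC(C)(C)NC=S)CC1`: > 100000 nM (a limit)
- Compound 2 `CC1=CC[C@@H]([C@@](C)(O)CCCC(C)(C)NC(=S)N/N=C\c2ccc(O)cc2)CC1`: > 100000 nM (a limit)

Neither compound has a numerical reading, and both sit at the same limit, as the limit of > 100000 nM in this assay, at which 2 of the 2 values shown sit, records. In this assay compound 2 stands at > 100000 nM, which is a limit and not a number. Among the measured compounds shown here, the only other value available, that of compound 1, is a limit too, so no measured step is available for comparison.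

The next compound is compound 3 `CC1=CC[C@@H]([C@@](C)(O)CCCC(C)(C)NC(=S)N/N=C\c2ccc([N+](=O)[O-])cc2)CC1`, which has not yet been measured. It keeps the framework of compound 2 but carries nitro in place of hydroxy on an aromatic carbon, para to a large group, turning 4-hydroxyphenyl into 4-nitrophenyl (nitro in place of hydroxy on an aromatic carbon).

With only the limit of > 100000 nM in this assay, at which 2 of the 2 values shown sit, to go on, no step beyond the scatter is expected in this assay, and no direction is favoured. The estimated step, a number no higher from compound 2 to compound 3 (the limit leaves the size open), is expected to be small. For compound 3 the estimated value is 100000 nM, with an expected range from 30000 nM to 200000 nM.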

Compound 3, concentration lethal to 50% of the cells: 45500 nM
The estimate for compound 3 lay 2.2-fold (0.34 log units) above the measured number, within the range that was stated.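

In this assay, the swap of hydroxy for nitro on the aromatic carbon para to a large group gives an at least 2.1-fold lower number from compound 2 to compound 3 (0.34 log units; beyond the scatter), so a change at this one place is enough to bring a numerical reading and more toxicity in this test. Compound 1 and compound 2 stood only at limits, so they could not show that this series can produce a number in this test at all, nor that the aromatic ring is a place where the read-out responds. The true size of the step stays unknown, and it can be stated only as a minimum, because the starting point of compound 2 is a limit and not a number: the limit of > 100000 nM in this assay, at which 2 of the 3 values shown sit.

The compounds shown hold only hydroxy and nitro at this place, so it remains open how an amine, a methoxy group, a chlorine atom or a nitrile would read there. Also open, as far as these compounds go, is whether nitro would give a similar reading at another place on the ring, or on a core with a different chain.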